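Trimming the Alkyl Chain: What Compound 4 Should Show

A few compounds are considered here, and "the series" means these few. Any claim that something is new, unique, unknown or untested is made for them only; others in the source may bear on it.

Measured compounds:
Compound 1, `CCC/C(C)=N\Nc1nc(-c2cccc([N+](=O)[O-])c2)cs1`: 1200000 nM
Compound 2, `C/C(CC(C)C)=N/Nc1nc(-c2cccc([N+](=O)[O-])c2)cs1`: 1130000 nM
Compound 3, `CCCCC/C(CC)=N\Nc1nc(-c2cccc([N+](=O)[O-])c2)cs1`: 1470000 nM

Of the compounds shown here, three on a shared core have been tested in a functional assay, with a stated time of 90 min; on this read-out lower numbers stand for an effect already at smaller amounts and higher numbers for an effect only at larger amounts of compound. Compound 1 gives 1200000 nM, compound 2 gives 1130000 nM, and compound 3 gives 1470000 nM. All three numbers lie close together, and none of the gaps between them exceeds the usual scatter, so no order among them can be claimed.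

Compound 1 differs from compound 2 by hydrogen in place of methyl on a saturated chain carbon bound to two saturated chain carbons. That change produced a 1.1-fold higher number from compound 2 to compound 1 (0.03 log units; within the scatter). The difference between the cores of compound 2 and compound 3 is not broken down here; their two values simply sit within the scatter of one another.

Compound 4, `CCCC/C(CC)=N\Nc1nc(-c2cccc([N+](=O)[O-])c2)cs1`, has not yet been measured. It differs from compound 3 by hydrogen in place of methyl on a saturated chain carbon, four bonds along the chain from a carbon with a double bond to nitrogen. Among the compounds with values here, this is the same kind of change as the one from compound 2 to compound 1, though the surroundings differ: in the earlier pair the methyl left a saturated chain carbon bound to two saturated chain carbons, whereas here it leaves a saturated chain carbon four bonds along the chain from a carbon with a double bond to nitrogen.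

Because a 1.1-fold higher number from compound 2 to compound 1 (0.03 log units; within the scatter) was within the scatter, a similarly small step is expected, namely a 1.1-fold lower number from compound 3 to compound 4 (0.05 log units; within the scatter). Compound 4 is therefore estimated at 1300000 nM, with a likely range from 600000 nM to 2800000 nM.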

Compound 4, half-maximal effective concentration: 1560000 nM
Beside the measured number, compound 4's estimate is 1.2-fold (0.08 log units) below it; the measured number falls inside the stated range.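

In this assay, putting hydrogen in place of methyl on a saturated chain carbon, four bonds along the chain from a carbon with a double bond to nitrogen, gives a 1.1-fold higher number from compound 3 to compound 4 (0.03 log units; within the scatter). Set beside the earlier case, the same exchange of methyl for hydrogen reads alike on the two cores, although it sits at a different place on the chain in each: the same change on two cores in this assay, a 1.1-fold higher number (0.03 log units; within the scatter) from compound 2 to compound 1 and a 1.1-fold higher number (0.03 log units; within the scatter) from compound 3 to compound 4, 1.0-fold (0.00 log units) apart, within the scatter of two such steps. This shows that, in both pairs, the change gave no step beyond the scatter, but it does not show that the change has a real effect of a consistent size, and two pairs cannot establish that the result would carry over to other cores in the series.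

The compounds shown all carry saturated chains and give numbers close together, so they leave open whether any change on this part of the molecule could produce a step beyond the scatter. As far as these compounds go, an amine or a carboxylic acid on the chain, a longer chain, or a ring in place of the chain could each test this, and what any of them would do in this assay remains unknown.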